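A few compounds are considered here, and "the series" means these few. Any claim that something is new, unique, unknown or untested is made for them only; others in the source may bear on it.

Of the compounds shown here, three have so far been measured in an ADME assay on A549 cells (Homo sapiens) for cytotoxicity, read by MTT assay, with a stated time of 24 h, tested at 2000 ug/mL; a higher number here means a weaker effect of the compound at the concentration tested, a lower number a stronger effect. Compound 1 `CO[C@H]1O[C@@H]([C@H](N=[N+]=[N-])C(=O)OCc2ccccc2)[C@@H](OCc2ccccc2)[C@@]2(OCc3ccccc3)[C@@H](OCc3ccccc3)CO[C@@H]12` gives 25%, compound 2 `CC(=O)Nc1nc(Cl)c2c(ncn2[C@@H]2O[C@@H]([C@H](N=[N+]=[N-])C(=O)OCc3ccccc3)[C@@H](OCc3ccccc3)[C@@]3(OCc4ccccc4)[C@@H](OCc4ccccc4)CO[C@@H]23)n1` gives 7.32%, and compound 3 `COC(=O)[C@@H](N=[N+]=[N-])[C@@H]1O[C@@H](n2cnc3nc(NC(C)=O)nc(Cl)c32)[C@@H]2OC[C@H](OCc3ccccc3)[C@]2(OCc2ccccc2)[C@@H]1OCc1ccccc1` gives 15.1%. On these numbers compound 3 stands second highest of three, with compound 2 nearest and compound 1 furthest, and both gaps lie within the scatter. Among the compounds with values here, the only step between measured compounds, a number 7.8 percentage points higher from compound 2 to compound 3 (within the scatter), concerns hydrogen in place of phenyl, not the configuration of a stereocentre. Compound 4 `COC(=O)[C@H](N=[N+]=[N-])[C@@H]1O[C@@H](n2cnc3nc(NC(C)=O)nc(Cl)c32)[C@@H]2OC[C@H](OCc3ccccc3)[C@]2(OCc2ccccc2)[C@@H]1OCc1ccccc1` differs from compound 3 in this way: the two compounds have the same atoms and bonds; at least one stereo element is drawn with a configuration in one of them and without one in the other: 1 of 8 stereo elements differ; a stereocentre at a saturated chain carbon is drawn S in compound 3 and R in compound 4. Within the data shown here, no measured step bears on a change of configuration, so no step beyond the scatter is expected in this assay. The expected step of a number 0.1 percentage points lower from compound 3 to compound 4 (within the scatter) is therefore small. For compound 4 the estimate is 15%, within a range from 4% to 30%.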

Compound 4, a percentage reported as activity, at one concentration (the size of the read-out at that concentration, not a potency): 21.3%
The estimate for compound 4 lay 6.3 percentage points below the measured number; the range from low to high includes it.
By their numbers in this assay, from the lowest: compounds 2, 3, 4 and 1 (each within the scatter of the next, the first and the last beyond it).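

In this assay, the change of configuration at this saturated chain carbon, from S to R, goes with a number 6.2 percentage points higher from compound 3 to compound 4 (within the scatter). Within the data shown here, this is the first measured pair at this position, and it gives no sign that the configuration there matters in this assay. One caution applies to that reading: the fact that one of compounds 3 and 4 is drawn with a defined configuration and the other without, at the place where they differ

Still open, from the compounds shown here alone, is whether the same change of configuration would give a similar result with the benzyl ester of compound 2. Also open, going by these compounds, is what an amine or a carboxylic acid at this chain carbon would do.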